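Adding a Second Chloro to the Aryl Ring of Compound 3

The source may report more compounds than this note shows. Statements on the series, on what has been measured and on what is new or still open speak of the compounds shown alone.

Compound 1 `COc1ccccc1/C=C1\CCC/C(=C\c2cccc(OC)c2OC)C1=O`: 31300 nM
Compound 2 `COc1cccc(/C=C2\CCC/C(=C\c3ccc(Cl)cc3Cl)C2=O)c1OC`: 49200 nM
Compound 3 `COc1ccc(/C=C2\CCC/C(=C\c3cccc(Cl)c3)C2=O)cc1OC`: 11900 nM

Compound 3 gives the lowest number of the three in an ADME assay on NHDF cells (Homo sapiens) for cytotoxicity, read by MTT assay, with a stated time of 72 h (on this read-out higher numbers stand for weaker inhibition and lower numbers for stronger inhibition), standing beyond the scatter from both compound 1 and compound 2. Compound 4 `COc1ccc(/C=C2\CCC/C(=C\c3cc(Cl)cc(Cl)c3)C2=O)cc1OC` differs from it only as chloro in place of hydrogen on an aromatic carbon, on an aromatic carbon meta to a chloro group. Among the measured compounds shown here, no measured step shows the same change; the nearest is a 1.6-fold higher number from compound 1 to compound 2 (0.20 log units; within the scatter), where more chlorine on that ring left the number within the scatter. Compound 4 is therefore expected to show a 1.2-fold higher number from compound 3 to compound 4 (0.07 log units; within the scatter), no step beyond the scatter. The estimate for compound 4 is 14000 nM, in the range 6000 nM to 35000 nM.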

Compound 4, half-maximal inhibitory concentration: 8300 nM
Beside the measured number, compound 4's estimate is 1.7-fold (0.23 log units) above it, and the stated range covers the measured number.
By their numbers in this assay, from the lowest: compounds 4 and 3 (each within the scatter of the next); then compounds 1 and 2 (each within the scatter of the next).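

In this assay the change from 3-chlorophenyl to 3,5-dichlorophenyl gives a 1.4-fold lower number from compound 3 to compound 4 (0.16 log units; within the scatter) on this ring. This is the first step shown in which chloro replaces only a hydrogen, and it shows that this position, meta to a chloro group, accepts a second chloro with no change beyond the scatter. Nothing measured here bears on why the number holds. On these data alone, whether an amine or a carboxylic acid in place of this chloro would move the number beyond the scatter stays open, as does the effect of a second chloro placed elsewhere on this ring.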